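A second methoxy on a compound known only as a limit

The source may hold more compounds than are shown below. What is called first, only, known or untested is meant among the compounds shown, and "the series" means these compounds.

Compound 1, `COc1cccc(/C(=C\c2cn(C(C)=O)c3ccc(OCc4ccccc4)cc23)C(=O)O)c1`, is known only through a limit: in a functional assay on M14 cells (Homo sapiens) for cytotoxicity, read by MTT assay, with a stated time of 72 h (a lower number here means a stronger inhibitor, a higher number a weaker inhibitor), compound 1 gives > 100000 nM, which is the limit of the measurement and not a number. Its one measured relative, compound 2 `CC(=O)n1cc(/C=C(/C(=O)O)c2ccccc2)c2cc(OCc3ccccc3)ccc21`, likewise gives > 100000 nM in this assay, again a limit. The step from compound 1 to compound 2, a step that the two limits leave unreadable from compound 1 to compound 2, cannot be read, since both ends rest on (the limit of > 100000 nM in this assay, at which 2 of the 2 values shown sit).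

Compound 3, `COc1ccc(/C(=C\c2cn(C(C)=O)c3ccc(OCc4ccccc4)cc23)C(=O)O)cc1OC`, differs from compound 1 by methoxy in place of hydrogen on an aromatic carbon; read one bond further out, the change is 3-methoxyphenyl to 3,4-dimethoxyphenyl, with the entering group ortho to a methoxy group and para to a large group. Going by the values given here, no measured step bears directly on this change, and the only step in hand, from compound 1 to compound 2, is unreadable. With compound 1 at the limit, the expected step from compound 1 to compound 3 is a step that the limit leaves unreadable from compound 1 to compound 3, essentially no movement that could be seen. Compound 3 is therefore expected to give about 150000 nM in this assay, within a range from 40000 nM to 600000 nM, and most likely to be reported once more as a limit.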

Compound 3, half-maximal inhibitory concentration: 65500 nM
For compound 3 the middle estimate is 2.3-fold (0.36 log units) above the measured one, and the stated range covers the measured number.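

Going by these compounds alone, compound 3 is the only one of the three compounds with a number rather than a limit in this assay, so the methoxy entering ortho to a methoxy group and para to a large group gives the first readable step: an at least 1.5-fold lower number from compound 1 to compound 3 (0.18 log units; that floor lies within the scatter). The wider change from phenyl to 3,4-dimethoxyphenyl reads the same way: an at least 1.5-fold lower number from compound 2 to compound 3 (0.18 log units; that floor lies within the scatter). Each of these steps is only a floor, and although the real size could be larger, the floor itself lies within the scatter, so the result does not by itself establish a real change, with only one end of each step measured as a number: the limit of > 100000 nM in this assay, at which 2 of the 3 values shown sit.

Within the data shown here, the step between the two limits still cannot be read, so what the single methoxy of compound 1 contributes relative to the phenyl of compound 2 stays open. Also open, as far as these compounds go, is whether another group entering at the same place, such as a hydroxyl, a fluorine or an amine, would move the number as far as the methoxy of compound 3 does, or further.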